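Removing a Bromine from a Cytotoxic Thiocyanate

The source may report more compounds than this note shows. Statements on the series, on what has been measured and on what is new or still open speak of the compounds shown alone.

Compound 2 `N#CSc1c(-c2ccc(Br)cc2)nc2sc(Cc3ccc(Cl)cc3)nn12`: 22000 nM
Compound 1 `Clc1ccc(Cc2nn3cc(-c4ccccc4)nc3s2)cc1`: > 250000 nM

Among the measured compounds shown here, in a functional assay on HeLa cells (Homo sapiens) for cytotoxicity, with a stated time of 72 h (on this read-out higher numbers stand for weaker inhibition and lower numbers for stronger inhibition), compound 2 gives the only number, 22000 nM. Compound 1 gives only a limit in this assay, > 250000 nM, so no number is known for it; this matters as the limit of > 250000 nM in this assay, at which 1 of the 2 values shown sits. Compound 3 `N#CSc1c(-c2ccccc2)nc2sc(Cc3ccc(Cl)cc3)nn12` differs from compound 2 by hydrogen in place of bromo on an aromatic carbon. For the measured compounds named here, no measured pair shows this change, so its size is uncertain; a modest loss, somewhat beyond the scatter, is expected. Compound 3 is therefore expected to give 45000 nM, between 15000 nM and 150000 nM. The expected step is a 2.0-fold higher number from compound 2 to compound 3 (0.31 log units; beyond the scatter).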

Compound 3, half-maximal inhibitory concentration: 12000 nM
Beside the measured number, compound 3's estimate is 3.8-fold (0.57 log units) above it; the measured number lies below the stated range.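

In this assay, going from 4-bromophenyl to phenyl gives a 1.8-fold lower number from compound 2 to compound 3 (0.26 log units; within the scatter), so the bromo group makes no difference that can be told from scatter. The large difference lies with the other change, cyanosulfanyl in place of hydrogen on an aromatic carbon, which gives an at least 20-fold lower number from compound 1 to compound 3 (1.31 log units; beyond the scatter). For compound 1 the value is a limit, not a number: the limit of > 250000 nM in this assay, at which 1 of the 3 values shown sits.

From the compounds shown here alone, it remains open how an amine or a carboxylic acid would behave in place of the bromo. Going by these compounds, whether a group such as a carboxamide could stand in for cyanosulfanyl is also open.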